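Dropping the chloro from compound 2: what to expect

The source may report more compounds than this note shows. Statements on the series, on what has been measured and on what is new or still open speak of the compounds shown alone.

Measured compounds:
compound 1, `COc1ccc(OC)c(/C=C/c2nnc(Nc3ccc(Cl)cc3)o2)c1`, "not determined" (no result reported)
compound 2, `COc1ccc(OC)c(/C=C/C(=O)N/N=C/c2ccc(Cl)cc2)c1`, > 100000 nM

Two compounds are shown, but only one carries a number-like entry. For compound 1 the entry in a functional assay on HOP-92 cells (Homo sapiens) for antiproliferative activity, read by sulforhodamine B assay, with a stated time of 48 h (on this read-out lower numbers stand for higher toxicity in this test and higher numbers for lower toxicity in this test), reads "not determined" (no result reported), so no result was reported. In this assay compound 2 gives > 100000 nM, and this is a limit of the assay rather than a number. Compound 2 therefore sits at the edge of what the test can report, as the evidence summary states: the limit of > 100000 nM in this assay, at which 1 of the 2 values shown sits. The second compound is not a neighbour of the first by any single change, so nothing can be said of a step between them beyond what the two entries show.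

The compound still to be tested is compound 3, `COc1ccc(OC)c(/C=C/C(=O)N/N=C/c2ccccc2)c1`. Its difference from compound 2 is hydrogen in place of chloro on an aromatic carbon. Within the data shown here, no measured step is available for such a change here, so the expectation rests only on where compound 2 stands. Since compound 2 already shows only a limit, the step from compound 2 to compound 3 is expected to be a step that the limit leaves unreadable from compound 2 to compound 3, that is, no change beyond the scatter. For compound 3 the estimate in this assay is 150000 nM, within 40000 nM to 500000 nM, and it is expected that the assay will again report only a limit.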

Compound 3, concentration lethal to 50% of the cells: > 100000 nM
Compound 3 ended at the assay's limit (the forecaster's own chance of this, stated with the estimate: 80%); the middle value lies beyond the limit too.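

Compound 2 and compound 3 both end at a limit in this assay, not at a number, so no step can be read between them for hydrogen in place of chloro: the limit of > 100000 nM in this assay, at which 2 of the 3 values shown sit.

The compounds shown leave open whether 4-chlorophenyl and phenyl differ at all in this assay, and where the true values of compound 2 and compound 3 lie.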